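A few compounds are considered here, and "the series" means these few. Any claim that something is new, unique, unknown or untested is made for them only; others in the source may bear on it.

Compound 1 `Cc1c(C(C)OC(=O)NC2CCCCC2)oc2ncnn12` gives 3160 nM in a functional assay on CHO cells for antagonist activity at metabotropic glutamate receptor 5 (Homo sapiens), read by calcium flux; on this read-out lower numbers stand for stronger inhibition and higher numbers for weaker inhibition. Compound 2 `Cc1c(C(C)OC(=O)Nc2ccccc2)oc2ncnn12` gives 63.1 nM in this assay.

Compound 2 stands lowest of the two numbers in this assay; its nearest neighbour is compound 1, separated by a 50-fold lower number from compound 1 to compound 2 (1.70 log units; beyond the scatter). Compound 3 `Cc1c(C(C)OC(=O)Nc2ccccc2)oc2nc(Cl)nn12` differs from compound 2 by chloro in place of hydrogen on an aromatic carbon. Within the data shown here, the one measured step does not bear on this change, as it concerns the exchange of cyclohexyl for phenyl elsewhere in the molecule, so nothing in the data speaks for a shift beyond the scatter. Compound 3 is therefore expected at 50 nM, between 15 nM and 200 nM, an estimated step of a 1.3-fold lower number from compound 2 to compound 3 (0.10 log units; within the scatter).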

Compound 3, half-maximal inhibitory concentration: 10 nM
Compound 3: middle estimate off by 5.0-fold (0.70 log units), on the high side; the whole stated range lies above it.
By their numbers in this assay, from the lowest: compound 3; then compound 2; then compound 1.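

Compound 1 and compound 2 both carry hydrogen on the aromatic carbon between two ring nitrogen atoms, so they said nothing about this position. In this assay chloro on this carbon gives a 6.3-fold lower number from compound 2 to compound 3 (0.80 log units; beyond the scatter) and so shows that the position accepts a substituent and that the number responds to it. No measurement at hand gives a reason for this step.

Going by these compounds, whether methyl, bromo or an amine on the same carbon would move the number the same way stays open. So does whether chloro gives a similar step with cyclohexyl in place of phenyl on the amide-type nitrogen.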